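The source may report more compounds than this note shows. Statements on the series, on what has been measured and on what is new or still open speak of the compounds shown alone.

The measured compounds and their values in a functional assay on the whole organism with Mus musculus as the target; a lower number here means that less compound is needed, a higher number that more compound is needed for the effect:
compound 1, `Cc1c(C)c2c(c(N(C)C)c1N)CC(C)(C)O2`, gives 22.3 mg/kg
compound 2, `Cc1c(C)c2c(c(C)c1N)CC(C)(CSc1ccncc1)O2`, gives 19.9 mg/kg
compound 3, `Cc1c(C)c2c(c(C)c1N)CC(C)(CSc1nc3ccccc3s1)O2`, gives 33.7 mg/kg

Compound 2 has the lowest of the three numbers, yet its nearest neighbour, compound 1, and its furthest, compound 3, both lie within the usual scatter of repeated measurements, so none of the three can be called more or less potent than another on these numbers. Within the data shown here, the three compounds differ from one another in more than one place, and no pair that differs in a single place has been measured, so no step of known size is available.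

Compound 4, `Cc1c(C)c2c(c(C)c1N)CC(C)(CCN(C)C)O2`, has not yet been measured in this assay. It differs from compound 2 in one place: (dimethylamino)methyl in place of (pyridin-4-yl)sulfanyl on a saturated chain carbon bound to a saturated ring carbon. Since every measured compound, whatever group sits on the saturated chain carbon, gives a number within the scatter of the others, no step beyond the scatter is expected in either direction when going from compound 2 to compound 4. For compound 4 the estimate is 22 mg/kg, within a range from 10 mg/kg to 45 mg/kg. The expected step is a 1.1-fold higher number from compound 2 to compound 4 (0.04 log units; within the scatter).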

Compound 4, dose for 50% inhibition: 19 mg/kg
Estimate against measurement, compound 4: 1.2-fold (0.06 log units) above; the range from low to high includes it.
By their numbers in this assay, from the lowest: compounds 4, 2, 1 and 3 (each within the scatter of the next).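

Among these compounds, the step is the first single-place comparison available in this assay: a 1.0-fold lower number from compound 2 to compound 4 (0.02 log units; within the scatter), so putting (dimethylamino)methyl in place of (pyridin-4-yl)sulfanyl on a saturated chain carbon bound to a saturated ring carbon leaves the number within the scatter. The group that leaves carries a six-membered aromatic ring and a sulfur atom, while the group that enters has no ring, no sulfur and fewer heavy atoms, so for this pair neither the ring nor the sulfur is required to hold the number where it stands. Nothing available explains why the two groups give matching numbers.

The compounds shown leave open how far this tolerance extends, since they do not tell whether a carboxylic acid or a longer chain ending in a primary amine at the same place would also stay within the scatter of compound 2. Going by these compounds, they also do not show what a plain methyl at this place would give on the core of compound 2, so the contribution of either group against a bare carbon chain remains unknown.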